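Cyanomethyl in Place of Hydrogen at the Chain Nitrogen

This account rests on a few compounds, and the source may have more. Where it says the series, first, only, none or still open, it means among the compounds named here.

Compound 2 `COc1ccc(-c2cc3c(OC)cc(OC)cc3n(C)c2=O)cc1` shares its core with compound 1 `COc1ccc(-c2cc3cccc(OC)c3nc2O)cc1` and compound 3 `COC(=O)CCn1c(=O)c(-c2ccc(OC)cc2)cc2c(OC)cc(OC)cc21`. In a functional assay on U-373MG ATCC cells for cytotoxicity against U373 MG (Homo sapiens), read by colorimetric assay and MTT assay (a higher number here means a weaker inhibitor, a lower number a stronger inhibitor), compound 2 gives 10000 nM, compound 1 gives 10000 nM and compound 3 gives 10000 nM, so compound 2 stands level with both of them. Among the measured compounds shown here, the only measured step, no change at the digits printed from compound 2 to compound 3 (within the scatter), shows that placing (methoxycarbonyl)methyl on the saturated chain carbon bound to the aromatic nitrogen leaves the reading unchanged. Compound 4 `COc1ccc(-c2cc3c(OC)cc(OC)cc3n(CCC#N)c2=O)cc1` differs from compound 2 by cyanomethyl in place of hydrogen on a saturated chain carbon bound to an aromatic nitrogen. This change sits at the same place as that measured step, so the step expected in this assay is none beyond the scatter, no change at the digits printed from compound 2 to compound 4 (within the scatter). Compound 4 is therefore estimated at 10000 nM, within 5000 nM to 20000 nM.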

Compound 4, half-maximal inhibitory concentration: 10000 nM
The estimate for compound 4 equals the measured number at the digits printed; low and high end bracket the measured number.
By their numbers in this assay, from the lowest: compounds 1, 2, 3 and 4 (each within the scatter of the next).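

In this assay, the cyanomethyl change gives no change at the digits printed from compound 2 to compound 4 (within the scatter), and exchanging methoxycarbonyl for cyano gives no change at the digits printed from compound 3 to compound 4 (within the scatter). A second, quite different chain end thus reads the same at this place as the methoxycarbonyl end and the plain methyl of compound 2, so the earlier single step no longer stands alone. From the compounds shown here alone, whether an amine or a carboxylic acid at the end of this chain, or a longer chain, would shift the reading stays open. Nothing measured here offers an explanation for these readings.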